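The source may hold more compounds than are shown below. What is called first, only, known or untested is meant among the compounds shown, and "the series" means these compounds.

Compound 1 `C=C1CCCC(C)(C)C1CC[C@]1(C)CC[C@@H]([C@@H](C)C(=O)O)OO1` gives in a functional assay on MOLT-4 cells (Homo sapiens) for cytotoxicity, read by colony formation (a lower number here means a stronger inhibitor of growth, a higher number a weaker inhibitor of growth), only a limit, > 5000 nM, and no number of its own. It therefore stands at the limit of > 5000 nM in this assay, at which 1 of the 2 values shown sits. Compound 2 `C=C1CCC[C@@H]2[C@@H](CC[C@@]3(C)CC[C@H]([C@H](C)C(=O)O)OO3)[C@H](C)CC[C@@]12C` gives 840 nM in this assay. Compound 3 `C=C1CCCC(C)(C)C1CC[C@@]1(C)CC[C@H]([C@@H](C)C(=O)O)OO1` has the same atoms and bonds as compound 1 and differs only in configuration: the two compounds have the same atoms and bonds; at least one stereo element is drawn with a configuration in one of them and without one in the other: 2 of 4 stereo elements differ; a stereocentre at a saturated ring carbon is drawn R in compound 1 and S in compound 3; a stereocentre at a saturated ring carbon is drawn S in compound 1 and R in compound 3. Within the data shown here, no measured pair shows how such an inversion moves this assay, so the expectation is an at least 1.2-fold lower number from compound 1 to compound 3 (0.09 log units; that floor lies within the scatter), a modest shift toward stronger inhibition at most. Compound 3 is estimated at 4000 nM, with a range from 800 nM to 20000 nM.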

Compound 3, concentration for 50% growth inhibition: 2160 nM
Compound 3: the middle estimate sits 1.9-fold (0.27 log units) above what was measured; low and high end bracket the measured number.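

Inverting the two stereocentres at saturated ring carbons, with atoms and bonds unchanged, gives an at least 2.3-fold lower number from compound 1 to compound 3 (0.36 log units; beyond the scatter) in this assay, the first sign that configuration alone moves this read-out. The size of this step is only a floor: the limit of > 5000 nM in this assay, at which 1 of the 3 values shown sits. The comparison also carries a caveat about how the two compounds are drawn: the fact that one of compounds 1 and 3 is drawn with a defined configuration and the other without, at the place where they differ.

Which of the two stereocentres carries the step stays open. So does how a methyl ester or an amide in place of the carboxylic acid would read in this assay.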